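Swapping the Amide Aryl Group in a Series Without Measurable Cytotoxicity

The source may report more compounds than this note shows. Statements on the series, on what has been measured and on what is new or still open speak of the compounds shown alone.

Three compounds share one core and differ only in the groups they carry. Compound 1 `CCCCCN1C(=O)C/C(=C\c2cccc(C(=O)Nc3cccc(F)c3)c2)C1=O` gives > 100000 nM in an ADME assay on HCT-116 cells (Homo sapiens) for cytotoxicity, read by MTT assay, with a stated time of 72 h (a lower number here means a stronger inhibitor, a higher number a weaker inhibitor), which is a limit of the assay rather than a number. Compound 2 `COc1ccc(NC(=O)c2cccc(/C=C3\CC(=O)N(c4ccc(C)cc4)C3=O)c2)cc1` also stops at the limit, giving > 100000 nM in this assay. Compound 3 `COc1ccc(NC(=O)c2cccc(/C=C3\CC(=O)N(c4ccccc4)C3=O)c2)c(C)c1` likewise reaches only the limit, > 100000 nM in this assay. Indeed (the limit of > 100000 nM in this assay, at which 3 of the 3 values shown sit), so no compound stands apart from another. Compound 4 `Cc1ccc(NC(=O)c2cccc(/C=C3\CC(=O)N(c4ccccc4)C3=O)c2)cc1` is not yet measured; it carries 4-methylphenyl in place of 4-methoxy-2-methylphenyl on an amide-type nitrogen. Going by the values given here, since every value shown is a limit, no step of any size is visible, and none beyond the scatter is expected. Compound 4 is therefore expected at 150000 nM, between 50000 nM and 500000 nM, most likely reported only as a limit again. The expected step that the limit leaves unreadable from compound 3 to compound 4 means no change beyond the scatter.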

Compound 4, half-maximal inhibitory concentration: > 100000 nM
Compound 4 was reported as a limit; the forecaster's own chance of this, stated with the estimate: 85%; the middle value is on the limit's open side.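

Compound 3 and compound 4 both sit at an assay limit, so no step between them can be read: the limit of > 100000 nM in this assay, at which 4 of the 4 values shown sit.

The compounds shown leave open whether any group on the shared core gives a measurable value.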